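This account rests on a few compounds, and the source may have more. Where it says the series, first, only, none or still open, it means among the compounds named here.

In a functional assay on Ehrlich cells (Mus musculus) for inhibition (on this read-out higher numbers stand for weaker inhibition and lower numbers for stronger inhibition), compound 3 `CC(=O)c1ccc2c(O)c(C(=O)O)cnc2c1` gives 794000 nM, the second highest of the three numbers. Compound 2 `O=C(O)c1cnc2cc(O)ccc2c1O` gives 912000 nM, and the move a 1.1-fold lower number from compound 2 to compound 3 (0.06 log units; within the scatter) is within the scatter. Among the measured compounds shown here, compound 1 `O=C(O)c1cnc2cc(OCc3c(Cl)c(Cl)c(Cl)c(Cl)c3Cl)ccc2c1O` gives 42700 nM, the only number that stands apart from compound 3 in this assay. Compound 4 `NC(=O)c1ccc2c(O)c(C(=O)O)cnc2c1` differs from compound 3 by amino in place of methyl on a carbonyl carbon. For the measured compounds named here, no measured step exchanges groups on a carbonyl carbon; the one step that touches this position of the shared core, hydroxy to acetyl, stayed within the scatter. On that basis the step of a 1.0-fold higher number from compound 3 to compound 4 (0.00 log units; within the scatter) is expected to stay within the scatter as well, with no clear direction. Compound 4 is therefore estimated at 800000 nM, with a range from 300000 nM to 2000000 nM in this assay.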

Compound 4, half-maximal inhibitory concentration: 5750000 nM
The estimate for compound 4 lay 7.2-fold (0.86 log units) below the measured number, outside the stated range (above it).
By their numbers in this assay, from the lowest: compound 1; then compounds 3 and 2 (each within the scatter of the next); then compound 4.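

In this assay, among the compounds shown here, this place is not indifferent: amino in place of methyl on the carbonyl carbon gives a 7.2-fold higher number from compound 3 to compound 4 (0.86 log units; beyond the scatter) here, the first step beyond the scatter at this place. Measured against the hydroxy compound, carbamoyl gives a 6.3-fold higher number from compound 2 to compound 4 (0.80 log units; beyond the scatter) while acetyl gives only a 1.1-fold lower number from compound 2 to compound 3 (0.06 log units; within the scatter) on the same aromatic carbon, so these two carbonyl groups are not interchangeable here. No measurement on hand accounts for the weaker inhibition with carbamoyl.

Going by these compounds, whether a methylamino group, a dimethylamino group or a carboxylic acid at this place would stay near carbamoyl or near acetyl remains open.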